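This account rests on a few compounds, and the source may have more. Where it says the series, first, only, none or still open, it means among the compounds named here.

Within the data shown here, in an ADME assay on Vero cells (Chlorocebus sabaeus) for cytotoxicity (a lower number here means that less compound is tolerated, a higher number that more compound is tolerated), compound 1 (`CCCCCCCCCCSc1ncnc2c1ncn2C1CCCC1`) gives 8.04 ug/mL, the only number among the compounds sharing this core. For compound 2 (`C=CCn1cnc2c(SCCCCCCCCCC)ncnc21`) the entry reads "not determined" (no result reported), and for compound 3 (`CCCCCCCCCCSc1ncnc2c1ncn2C1CCCCC1`) it reads "not determined" (no result reported), so compound 3 stands without a number of its own. Compound 4 (`CCCCCCCCCCSc1ncnc2c1ncn2CC(=O)OCC`) has yet to be measured. It departs from compound 3 in one place, on an aromatic nitrogen: (ethoxycarbonyl)methyl in place of cyclohexyl on an aromatic nitrogen. Among the measured compounds shown here, no measured step guides this change in this assay, so only a modest shift towards more compound tolerated is expected, resting on compound 1 at 8.04 ug/mL as the sole anchor. The estimated value for compound 4 is 14 ug/mL, within a range of 5 ug/mL to 45 ug/mL.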

Compound 4, half-maximal cytotoxic concentration: > 62.5 ug/mL
Compound 4 was reported as a limit (the forecaster's own chance of this, stated with the estimate: 15%); middle value at least 4.4-fold (0.64 log units) away from the limit.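

In this assay, exchanging the cyclopentyl group for an (ethoxycarbonyl)methyl group gives an at least 7.7-fold higher number from compound 1 to compound 4 (0.89 log units; beyond the scatter). Among these compounds, this is the first readable step at this position, showing that the group on this nitrogen can change how much compound is tolerated. Compound 4 is reported only as a limit of the assay: the limit of > 62.5 ug/mL in this assay, at which 1 of the 4 values shown sits.

The step from compound 3 cannot be read, as compound 3 has no number of its own. Going by these compounds, whether the ester or the loss of the ring matters stays open, as does what a carboxylic acid or a plain ethyl group on this nitrogen would give.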